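The source may report more compounds than this note shows. Statements on the series, on what has been measured and on what is new or still open speak of the compounds shown alone.

Compound 1, with the structure `Oc1cccc(-c2cc(-c3ccsc3)cc(-c3ccccc3O)n2)c1`, was tested in a functional assay on HCT-15 cells (Homo sapiens) for cytotoxicity, read by CCK-8 assay; on this read-out higher numbers stand for weaker inhibition and lower numbers for stronger inhibition. In this assay compound 1 gives only a limit of the assay, > 50000 nM. Compound 2, the structure `Oc1ccc(-c2cc(-c3ccsc3)cc(-c3ccccc3O)n2)cc1`, carries the change (4-hydroxyphenyl in place of 3-hydroxyphenyl on an aromatic carbon). In this assay compound 2 likewise reaches only a limit, > 50000 nM. The step that the two limits leave unreadable from compound 1 to compound 2 therefore cannot be sized, because both ends sit at the limit of > 50000 nM in this assay, at which 3 of the 3 values shown sit.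

Compound 3 has the structure `Oc1ccc(-c2cc(-c3ccccn3)cc(-c3cccc(O)c3)n2)cc1`; how its core differs from that of compound 1 is not broken down here. In this assay compound 3 also returns only a limit, > 50000 nM.

Compound 4, the structure `Oc1ccc(-c2cc(-c3ccccn3)cc(-c3ccc(O)cc3)n2)cc1`, is not yet measured. It differs from compound 3 by 4-hydroxyphenyl in place of 3-hydroxyphenyl on an aromatic carbon, the same kind of change as that from compound 1 to compound 2, though the surroundings differ: in compound 1 the place is meta to a 2-hydroxyphenyl group and meta to a thiophen-3-yl group, whereas in compound 3 it is meta to a 4-hydroxyphenyl group and meta to a pyridin-2-yl group.

The measured step offers no readable size to carry over, so the expected step that the limit leaves unreadable from compound 3 to compound 4 for compound 4 rests only on the fact that every value shown, including that of compound 3 at > 50000 nM, sits at the limit of > 50000 nM in this assay, at which 3 of the 3 values shown sit. Compound 4 is accordingly estimated to give 100000 nM in this assay, most probably reported again only as a limit, within an expected range from 30000 nM to 400000 nM.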

Compound 4, half-maximal inhibitory concentration: > 50000 nM
Compound 4 gave a limit, no number (the forecaster's own chance of this, stated with the estimate: 85%); the middle value is on the limit's open side.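

No step can be read in this assay between compound 3 and compound 4, because both compounds stop at an assay limit, so their difference has no size: the limit of > 50000 nM in this assay, at which 4 of the 4 values shown sit.

The compounds shown leave open whether 4-hydroxyphenyl in place of 3-hydroxyphenyl changes cytotoxicity at all, as none of them gives a number that could be compared.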